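Replacing methylselanyl by sulfanyl on a quinazoline core

The source may hold more compounds than are shown below. What is called first, only, known or untested is meant among the compounds shown, and "the series" means these compounds.

Measured compounds:
compound 1 `COc1ccc(CNc2nc([Se]C)nc3ccccc23)cc1`, 33000 nM
compound 2 `C[Se]c1nc(NCc2ccccc2)c2ccccc2n1`, 74600 nM
compound 3 `CSc1ccc(CNc2nc([Se]C)nc3ccccc23)cc1`, 37900 nM

In a functional assay on HTB-54 cells (Homo sapiens) for cytotoxicity, read by MTT assay, with a stated time of 72 h (on this read-out higher numbers stand for weaker inhibition of growth and lower numbers for stronger inhibition of growth), compound 1 gives the lowest of the three numbers. Its nearest neighbour is compound 3, whose step a 1.1-fold higher number from compound 1 to compound 3 (0.06 log units; within the scatter) lies within the scatter; its furthest is compound 2, with a 2.3-fold higher number from compound 1 to compound 2 (0.35 log units; beyond the scatter). Compound 4 `COc1ccc(CNc2nc(S)nc3ccccc23)cc1` differs from compound 1 in this way: one sulfur atom in place of a group of 2 heavy atoms (1 carbon, 1 selenium; no ring), on an aromatic carbon, between two ring nitrogen atoms. None of the three measured steps touches this position: all of them, a 2.3-fold higher number from compound 1 to compound 2 (0.35 log units; beyond the scatter), a 1.1-fold higher number from compound 1 to compound 3 (0.06 log units; within the scatter) and a 2.0-fold lower number from compound 2 to compound 3 (0.29 log units; within the scatter), vary the group on the benzyl ring while the methylselanyl group stays. Within the data shown here, there is therefore no measured step from which the size or direction of the change to compound 4 can be read. The estimate for compound 4 is 45000 nM, with a range from 12000 nM to 170000 nM, which means an expected step of a 1.4-fold higher number from compound 1 to compound 4 (0.13 log units; within the scatter), with wide uncertainty.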

Compound 4, concentration for 50% growth inhibition: 13500 nM
For compound 4 the middle estimate is 3.3-fold (0.52 log units) above the measured one, and the stated range covers the measured number.
By their numbers in this assay, from the lowest: compound 4; then compounds 1, 3 and 2 (each within the scatter of the next, the first and the last beyond it).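

In this assay, the first change measured at the position between two ring nitrogen atoms, sulfanyl in place of methylselanyl, gives a 2.4-fold lower number from compound 1 to compound 4 (0.39 log units; beyond the scatter) and so lies beyond the scatter. The number therefore responds to this position as well as to the group on the benzyl ring, and here the shorter sulfanyl group gives the stronger inhibition of growth. No measurement shown offers an explanation for this step.

This single exchange removes the methyl carbon and replaces selenium with sulfur at once, so a methylsulfanyl group at this position would be needed to tell those two parts apart. From the compounds shown here alone, whether sulfanyl gives a similar step alongside the unsubstituted benzyl group of compound 2 remains open, as does the outcome with an amine or a longer alkylselanyl chain at this position.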